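The source may hold more compounds than are shown below. What is called first, only, known or untested is meant among the compounds shown, and "the series" means these compounds.

Compound 3, `N#Cc1c(Cl)nc(SCC(=O)Nn2c(COc3ccc(Cl)cc3Cl)nc3ccccc3c2=O)nc1-c1ccccc1`, is measured in a functional assay on the whole organism (strain albino) for inhibition, with Rattus norvegicus as the target, read by paw edema, with stated times of 1 h and 0.5 h, at a dose of 100 mg/kg by the oral route (on this read-out higher numbers stand for more inhibition at the one dose given (going by the name of the read-out) and lower numbers for less inhibition), and gives 53.9%. Its number lies within the scatter of the value of compound 2 and beyond the scatter below that of compound 1. Compound 1, `N#Cc1c(-c2ccccc2)nc(SCC(=O)Nn2c(COc3ccc(Cl)cc3Cl)nc3ccccc3c2=O)[nH]c1=O`, gives 80.8% in this assay, and compound 2, `N#Cc1c(-c2ccc(O)cc2)nc(SCC(=O)Nn2c(COc3ccc(Cl)cc3Cl)nc3ccccc3c2=O)[nH]c1=O`, gives 61.5%. The unmeasured compound 4, `N#Cc1c(Cl)nc(SCC(=O)Nn2c(COc3ccc(Cl)cc3Cl)nc3ccccc3c2=O)nc1-c1ccc(O)cc1`, differs from compound 3 by hydroxy in place of hydrogen on an aromatic carbon. Among the compounds with values here, one measured step bears directly on this change: a number 19.3 percentage points lower from compound 1 to compound 2 (beyond the scatter), which is the same exchange, hydroxy in place of hydrogen on an aromatic carbon, made on the other pair. Because that step read a number 19.3 percentage points lower from compound 1 to compound 2 (beyond the scatter), a drop of similar size, beyond the scatter, is expected when the same exchange is made on compound 3, though a single precedent leaves the size uncertain. Compound 4 is therefore estimated at 36% in this assay, with a range from 20% to 52%. This corresponds to an expected step of a number 17.9 percentage points lower from compound 3 to compound 4 (beyond the scatter).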

Compound 4, a percentage reported as inhibition, in the whole organism at one dose (the size of the read-out at that dose, not a potency): 67.3%
Compound 4: the middle estimate sits 31.3 percentage points below what was measured; measured number outside the range, above it.
By their numbers in this assay, from the lowest: compounds 3, 2 and 4 (each within the scatter of the next, the first and the last beyond it); then compound 1.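

In this assay the exchange of phenyl to 4-hydroxyphenyl has no fixed direction: on the core of compound 3 it reads a number 13.4 percentage points higher from compound 3 to compound 4 (beyond the scatter) and on the core of compound 1 it reads a number 19.3 percentage points lower from compound 1 to compound 2 (beyond the scatter) with the opposite sign. The earlier pair alone pointed to a loss with hydroxy at this place, para to a large group, but with two pairs no single sign holds for the change. What the hydroxy does here depends on the core that carries the ring, as the two steps show side by side: the same change on two cores in this assay, a number 19.3 percentage points lower (beyond the scatter) from compound 1 to compound 2 and a number 13.4 percentage points higher (beyond the scatter) from compound 3 to compound 4, 32.7 percentage points apart, beyond the scatter of two such steps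

The compounds shown leave open whether the same reversal would appear with a methoxy group, an amine or a fluorine atom at this place on the phenyl ring. Two pairs also cannot tell which of the differences between the two cores sets the direction of the step.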